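Swapping the aryl group on the alkene of compound 1

The source may hold more compounds than are shown below. What is called first, only, known or untested is meant among the compounds shown, and "the series" means these compounds.

Measured compounds:
compound 1, `COc1ccccc1/C=C(/Sc1ccc(C)cc1)C(=O)c1ccc(Cl)cc1`, 25000 nM
compound 2, `COc1ccccc1/C=C(/SCc1ccc(F)cc1)C(=O)c1ccc(Cl)cc1`, 10000 nM
compound 3, `COc1ccccc1/C=C(/SCc1ccc(Cl)c(Cl)c1)C(=O)c1ccc(Cl)cc1`, 10000 nM

In a functional assay on DU-145 cells (Homo sapiens) for inhibition, read by trypan blue exclusion, with a stated time of 96 h (a higher number here means a weaker inhibitor of growth, a lower number a stronger inhibitor of growth), compound 1 gives 25000 nM, the highest of the three numbers, so compound 1 is the weakest growth inhibitor among them. The measured steps both change the group on the sulfur: a 2.5-fold lower number from compound 1 to compound 2 (0.40 log units; beyond the scatter) and a 2.5-fold lower number from compound 1 to compound 3 (0.40 log units; beyond the scatter), while no change at the digits printed from compound 2 to compound 3 (within the scatter).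

Compound 4, `Cc1ccc(S/C(=C/c2ccc(N(C)C)cc2)C(=O)c2ccc(Cl)cc2)cc1`, changes a different part of the shared core of compound 1: 4-(dimethylamino)phenyl in place of 2-methoxyphenyl on a double-bonded chain carbon bound to a double-bonded chain carbon. Within the data shown here, no measured step touches this position, so the two recorded steps from compound 1 offer no direct guide, and no direction can be inferred from them. The expectation is therefore that compound 4 stays near compound 1, with a wide margin: a 1.3-fold lower number from compound 1 to compound 4 (0.10 log units; within the scatter) is the step expected. Compound 4 is estimated at 20000 nM in this assay, within a range of 5000 nM to 60000 nM.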

Compound 4, concentration for 50% growth inhibition: > 100000 nM
Compound 4 gave a limit, no number; the forecaster's own chance of this, stated with the estimate: 20%; middle value at least 5.0-fold (0.69 log units) away from the limit.
By their numbers in this assay, from the lowest: compounds 2 and 3 (each within the scatter of the next); then compound 1. At a limit, above all of these: compound 4.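

The group on the double-bonded chain carbon bound to a double-bonded chain carbon proves to matter in this assay, a point the changes on the sulfur could not show. Putting 4-(dimethylamino)phenyl in place of 2-methoxyphenyl gives an at least 4.0-fold higher number from compound 1 to compound 4 (0.60 log units; beyond the scatter), whereas the sulfur change gave a 2.5-fold lower number from compound 1 to compound 2 (0.40 log units; beyond the scatter), so the two changes move the number in opposite directions. For compound 4 the reading is a limit, not a number: the limit of > 100000 nM in this assay, at which 1 of the 4 values shown sits.

On these data alone, whether 4-methoxyphenyl or unsubstituted phenyl at this place would sit closer to compound 1 or to compound 4 stays open, so the nature of the group and where it sits on the ring cannot be told apart. Also open, as far as these compounds go, is whether 4-(dimethylamino)phenyl would give the same outcome with the 4-fluorobenzyl of compound 2 on the sulfur.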